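The compounds below may be only part of what the source reports. "The series", "measured", "known", "first", "only" and "open" are said of these compounds alone.

Working notes on the series. Of the compounds shown here, three sharing a core have been measured in a functional assay on the whole organism with Mus musculus as the target; on this read-out lower numbers stand for smaller maximal responses and higher numbers for larger maximal responses. Compound 1 `CN(C)CCCn1c(=O)n(C2OC(CO)[C@@H](O)[C@H]2O)c2nc(N)nc(O)c21` gives 63%. Compound 2 `C=CCSc1nc2c(O)nc(N)nc2n1C1OC(CO)[C@@H](O)[C@H]1O` gives 57%. Compound 3 `Cn1c(=O)n([C@@H]2O[C@H](CO)[C@H]3OC(C)(C)O[C@H]32)c2nc(N)nc(O)c21` gives 17%, the lowest of the three numbers; its gap to compound 2 and its wider gap to compound 1 both lie beyond the scatter, so compound 3 stands apart as the smallest maximal response seen so far.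

The next compound, compound 4 `CC1(C)O[C@@H]2[C@H](O1)[C@@H](CO)O[C@H]2n1c(=O)n(C/C=C/c2ccccc2)c2c(O)nc(N)nc21`, has not yet been measured in this assay. It differs from compound 3 in one place: 2-phenylethenyl in place of hydrogen on a saturated chain carbon bound to an aromatic nitrogen. Going by the values given here, no step between two measured compounds matches this change, so the direction can only be read loosely from the fact that the two compounds carrying larger groups on the core, compound 1 and compound 2, give the higher numbers.

On that basis compound 4 is expected to move upward by a moderate step, a number 18 percentage points higher from compound 3 to compound 4 (beyond the scatter), with the estimate for compound 4 at 35%, ranging from 10% to 65%.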

Compound 4, largest response reached (reported as maximal response), in percent of the reference or control that the assay uses: 10%
Estimate against measurement, compound 4: 25 percentage points above, within the range that was stated.
By their numbers in this assay, from the lowest: compounds 4 and 3 (each within the scatter of the next); then compounds 2 and 1 (each within the scatter of the next).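

In this assay the exchange of hydrogen for 2-phenylethenyl on a saturated chain carbon bound to an aromatic nitrogen amounts to a number 7 percentage points lower from compound 3 to compound 4 (within the scatter) and leaves the two compounds indistinguishable on this read-out. With the rest of the structure held fixed, this position therefore carries either methyl or 3-phenylprop-2-en-1-yl, with its six-membered aromatic ring and its double bond, without a difference in maximal response beyond the scatter. No measurement at hand accounts for this outcome.

Open, as far as these compounds go, is whether a carboxylic acid or a plain hexyl chain at this position would give the same picture as these two groups. Also open, from the compounds shown here alone, is whether the same exchange would read the same way on the differently substituted sugar part seen in compound 1 and compound 2.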